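The source may report more compounds than this note shows. Statements on the series, on what has been measured and on what is new or still open speak of the compounds shown alone.

Within the data shown here, compound 1 `COc1cc2cc(Oc3ccc(NC(=O)Nc4cccc(C(F)(F)F)c4)cc3)c(C)nc2cc1OC` is the only member of this small set with a fixed number: in a functional assay on NCI-H226 cells (Homo sapiens) for inhibition, read by sulforhodamine B assay, with a stated time of 48 h (on this read-out higher numbers stand for lower toxicity in this test and lower numbers for higher toxicity in this test), compound 1 gives 28800 nM. Compound 2 `COc1cc2cc(Oc3ccc(NC(=O)Nc4ccc(Cl)c(C(F)(F)F)c4)cc3)c(C)nc2cc1OC` did not reach a number at all. In this assay compound 2 gives > 32500 nM, which is a limit of the test rather than a measurement. Among the measured compounds shown here, the single step between measured compounds, chloro in place of hydrogen on an aromatic carbon, reads an at least 1.1-fold higher number from compound 1 to compound 2 (0.05 log units; that floor lies within the scatter), and it rests on (the limit of > 32500 nM in this assay, at which 1 of the 2 values shown sits), so it cannot be sized further. Compound 2 thus stands at the upper edge of the two values shown, known only as a limit.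

Compound 3 `COc1cc2cc(Oc3ccc(NC(=O)Nc4ccc(Cl)c(Cl)c4)cc3)c(C)nc2cc1OC` differs from compound 2 by chloro in place of trifluoromethyl on an aromatic carbon. For the measured compounds named here, only the step from compound 1 to compound 2 bears on this change, since it touched the same ring, and that step lay within the scatter. With both known values at or close to the limit, no step beyond the scatter is expected in this assay in either direction. Compound 3 is therefore expected near 35000 nM, between 18000 nM and 80000 nM. This estimate means a step that the limit leaves unreadable from compound 2 to compound 3, expected to stay within the scatter and most likely to end again at a limit.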

Compound 3, concentration lethal to 50% of the cells: 35800 nM
The estimate for compound 3 lay 1.0-fold (0.01 log units) below the measured number, within the range that was stated.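

In this assay compound 3 supplies what compound 2 could not: a fixed number for a 3,4-dichlorophenyl group on the amide-type nitrogen, so this substitution pattern can now be compared directly with the parent aryl group. Putting 3,4-dichlorophenyl in place of 3-(trifluoromethyl)phenyl gives a 1.2-fold higher number from compound 1 to compound 3 (0.09 log units; within the scatter), so this replacement does not move the number beyond the scatter. The effect of chloro in place of trifluoromethyl on its own, at the position ortho to a chloro group, cannot be read, because compound 2 is known only as a limit: the limit of > 32500 nM in this assay, at which 1 of the 3 values shown sits.

The compounds shown leave open whether any group at this position would move the number beyond the scatter in this assay, for example an amine or a carboxylic acid in place of the trifluoromethyl or chloro group. They also leave open whether a longer chain on the shared core, rather than a change on this aromatic ring, would shift the read-out at all.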